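This account rests on a few compounds, and the source may have more. Where it says the series, first, only, none or still open, it means among the compounds named here.

Working notes on the series, measured in a physicochemical assay, read by spectrophotometry, with a stated time of 30 min; a higher number here means a weaker inhibitor, a lower number a stronger inhibitor:

- compound 1 `O=C(CC(c1ccccc1Cl)c1c[nH]c2ccccc12)c1c(O)c2ccccc2oc1=O`: 39.6 ug/mL
- compound 2 `COc1ccc(C(CC(=O)c2c(O)c3ccccc3oc2=O)c2c[nH]c3ccccc23)c(OC)c1`: 13.2 ug/mL
- compound 3 `COc1ccc(OC)c(C(CC(=O)c2c(O)c3ccccc3oc2=O)c2c[nH]c3ccccc23)c1`: 19 ug/mL

Compound 2 shares the low end of the numbers with compound 3, the two lying within the scatter of each other: a 1.4-fold higher number from compound 2 to compound 3 (0.16 log units; within the scatter). Only compound 1 stands clearly apart.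

The next change gives compound 4 `N#Cc1ccc(C(CC(=O)c2c(O)c3ccccc3oc2=O)c2c[nH]c3ccccc23)cc1`: 4-cyanophenyl in place of 2,4-dimethoxyphenyl on a saturated chain carbon bound to an aromatic carbon and a saturated chain carbon, (4-cyanophenyl in place of 2,4-dimethoxyphenyl on a saturated chain carbon bound to an aromatic carbon and a saturated chain carbon).

Going by the values given here, no compound with a nitrile has been measured, so the closest evidence is the pair of modest steps that install a dimethoxyphenyl group on compound 1: a 3.0-fold lower number from compound 1 to compound 2 (0.48 log units; beyond the scatter) and a 2.1-fold lower number from compound 1 to compound 3 (0.32 log units; beyond the scatter). Among the compounds with values here, compound 4 loses both methoxy groups, and compound 1 at 39.6 ug/mL is the only measured compound without them. A modest move back towards a higher number is therefore expected in this assay, though on thin evidence.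

The expected change is a 2.3-fold higher number from compound 2 to compound 4 (0.36 log units; beyond the scatter).

For compound 4 the estimate is 30 ug/mL, with an expected range of 13 ug/mL to 70 ug/mL.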

Compound 4, half-maximal inhibitory concentration: 13.7 ug/mL
Estimate against measurement, compound 4: 2.2-fold (0.34 log units) above; low and high end bracket the measured number.
By their numbers in this assay, from the lowest: compounds 2, 4 and 3 (each within the scatter of the next); then compound 1.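

In this assay, the 4-cyanophenyl group matches both dimethoxyphenyl groups on this saturated chain carbon (a 1.0-fold higher number from compound 2 to compound 4 (0.02 log units; within the scatter); a 1.4-fold lower number from compound 3 to compound 4 (0.14 log units; within the scatter)). The methoxy groups are therefore not required for the low numbers at this position: compound 4 carries neither, yet it stands clearly apart from the 2-chlorophenyl compound (a 2.9-fold lower number from compound 1 to compound 4 (0.46 log units; beyond the scatter)). Going by these compounds alone, that leaves compound 1 as the only compound set apart, and no measurement at hand offers an explanation for this.

With a single chlorine-bearing group among the compounds shown, it remains open whether the chlorine itself or its placing on the ring sets compound 1 apart. Also open, going by these compounds, is whether an unsubstituted phenyl, or a phenyl carrying an amine or a carboxylic acid, would hold the same low numbers at this carbon.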